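The source may report more compounds than this note shows. Statements on the series, on what has been measured and on what is new or still open speak of the compounds shown alone.

Compound 1 `Fc1ccc(-c2ccc(-c3ccc(-c4nc5ccccc5[nH]4)cc3)cc2)cc1`: 41300 nM
Compound 2 `FC(F)(F)Oc1ccc(-c2ccc(-c3ccc(-c4nc5ccccc5[nH]4)cc3)cc2)cc1`: 39100 nM
Compound 3 `CN(C)c1ccc(-c2ccc(-c3ccc(-c4nc5ccccc5[nH]4)cc3)cc2)cc1`: 39300 nM

These three values come from a functional assay on KB cells (Homo sapiens) for inhibition, read by sulforhodamine B assay; on this read-out lower numbers stand for stronger inhibition of growth and higher numbers for weaker inhibition of growth. Compound 1 stands level with the other two, since a 1.1-fold lower number from compound 1 to compound 2 (0.02 log units; within the scatter) and a 1.1-fold lower number from compound 1 to compound 3 (0.02 log units; within the scatter) both lie within the scatter. Compound 4 `Oc1cccc2[nH]c(-c3ccc(-c4ccc(-c5ccc(F)cc5)cc4)cc3)nc12` keeps all of compound 1 and changes one place: hydroxy in place of hydrogen on an aromatic carbon. In words, this is hydroxy in place of hydrogen on an aromatic carbon, on the carbon-only ring of the fused system.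

For the measured compounds named here, no measured compound carries a hydroxy, so no step tests this change directly. The measured steps only exchange fluoro, trifluoromethoxy and dimethylamino at another place, and a 1.0-fold higher number from compound 2 to compound 3 (0.00 log units; within the scatter) was also within the scatter. They give indirect guidance at best: the core of compound 1 has so far tolerated change without a visible shift. No shift beyond the scatter is therefore expected, though the range stays wide. The expected change is a 1.2-fold lower number from compound 1 to compound 4 (0.07 log units; within the scatter). For compound 4 the estimate is 35000 nM, with an expected range from 12000 nM to 60000 nM.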

Compound 4, concentration for 50% growth inhibition: 6920 nM
The estimate for compound 4 lay 5.1-fold (0.70 log units) above the measured number, and the stated range ends above it.
By their numbers in this assay, from the lowest: compound 4; then compounds 2, 3 and 1 (each within the scatter of the next).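

In this assay, for the compounds shown here, hydroxy in place of hydrogen on an aromatic carbon of the carbon-only ring of the fused system gives a 6.0-fold lower number from compound 1 to compound 4 (0.78 log units; beyond the scatter), the first step in this set beyond the scatter. Compound 1, compound 2 and compound 3 differ only at another place, and all their steps stay within the scatter, so they gave no sign that the number could move at all; this single added group shows that it can. The data offer no measurement that explains the gain.

As far as these compounds go, it remains open whether the oxygen alone is enough, which a methoxy at the same place would test, or whether an amine there would give a similar step. Also open, from the compounds shown here alone, is whether the hydroxy would give a similar step alongside trifluoromethoxy or dimethylamino in place of fluoro.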